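Clearance notes: from compound 2 to compound 4

The source may hold more compounds than are shown below. What is called first, only, known or untested is meant among the compounds shown, and "the series" means these compounds.

Values from an in vitro ADME assay on microsomes from liver (Homo sapiens) for metabolic stability, tested at 0.2 uM (a lower number here means slower removal, a higher number faster removal of the compound), so far
- compound 1 `Cc1c(COc2ccnc(OCC3CCOCC3)c2)[nH]c2ccccc2c1=O` gives 95 mL/min/kg
- compound 2 `COC(C)(C)CCOc1cccc(OCc2[nH]c3ccccc3c(=O)c2C)c1` gives > 1000 mL/min/kg (a limit)
- compound 3 `Cc1c(COCCCCO)[nH]c2ccccc2c1=O` gives "not determined" (no result reported) (no number)

For compound 2 the record shows the limit of > 1000 mL/min/kg in this assay, at which 1 of the 3 values shown sits, and this is a limit, not a number. Its true position in this assay is therefore open on one side.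

Compound 4 `Cc1c(COc2cccc(OCC3CCOCC3)c2)[nH]c2ccccc2c1=O` has not yet been measured. It differs from compound 2 at one place: oxan-4-yl in place of 2-methoxy-2-methylpropyl on a saturated chain carbon bound to an oxygen on an aromatic ring. Read one bond further out, this is 3-methoxy-3-methylbutoxy to (oxan-4-yl)methoxy.

For the measured compounds named here, no measured pair isolates this change, so the expectation rests on very little. Going by the values given here, compound 1 also carries (oxan-4-yl)methoxy and gives 95 mL/min/kg in this assay, the only actual number available, which points to a large fall beyond the usual scatter rather than to no change. The expected change is an at least 3.3-fold lower number from compound 2 to compound 4 (0.52 log units; beyond the scatter), towards slower removal. Compound 4 is estimated at 300 mL/min/kg, with an expected range of 110 mL/min/kg to 800 mL/min/kg in this assay, and a reading at the limit remains possible.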

Compound 4, clearance: 214 mL/min/kg
The estimate for compound 4 lay 1.4-fold (0.15 log units) above the measured number; the range from low to high includes it.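

In this assay, the change from 3-methoxy-3-methylbutoxy to (oxan-4-yl)methoxy gives the series its first readable step, an at least 4.6-fold lower number from compound 2 to compound 4 (0.66 log units; beyond the scatter). Going by these compounds, the size of that step stays open on one side, since compound 2 carries only a limit and not a number: the limit of > 1000 mL/min/kg in this assay, at which 1 of the 4 values shown sits. Compound 4 gives 214 mL/min/kg, so the place on a saturated chain carbon bound to an oxygen on an aromatic ring now has a real number, and the step arises between two groups with the same heavy-atom, donor and acceptor counts, with oxan-4-yl bringing one six-membered non-aromatic ring where 2-methoxy-2-methylpropyl has no ring.

The compounds shown do not separate the presence of the ring from the loss of the open chain with its methoxy group, and this single step says nothing about how general the change is on other compounds of the series. Also open, on these data alone, is how an amine such as piperidin-4-yl, a carboxylic acid or a shorter chain would read at this place in this assay.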